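From 4-methoxyphenyl to 3,4-dimethoxyphenyl in compound 1

The source may hold more compounds than are shown below. What is called first, only, known or untested is meant among the compounds shown, and "the series" means these compounds.

Among the compounds with values here, in an ADME assay on HEK293 cells (Homo sapiens) for cytotoxicity, read by MTT assay, with a stated time of 48 h (a lower number here means a stronger inhibitor, a higher number a weaker inhibitor), compound 1 (`COc1ccc(-c2nc(SCC(=O)c3sc(-c4ccccc4)nc3C)[nH]c(=O)c2C#N)cc1`) gives 76200 nM, the only number available. For compound 2 (`COc1ccc(-c2nc(C)c(C(=O)CSc3nc(-c4ccc(OC)cc4)c(C#N)c(=O)[nH]3)s2)cc1`) the entry reads "not determined" (no result reported), and for compound 3 (`COc1ccc(-c2nc(SCC(=O)c3sc(-c4ccc(Cl)cc4)nc3C)[nH]c(=O)c2C#N)cc1`) it reads "not determined" (no result reported). Within the data shown here, neither has a reported result, so compound 1 cannot be ranked against a neighbour and no measured step is available as a guide.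

Compound 4 (`COc1ccc(-c2nc(SCC(=O)c3sc(-c4ccccc4)nc3C)[nH]c(=O)c2C#N)cc1OC`) awaits measurement in this assay. It differs from compound 1 in one place: methoxy in place of hydrogen on an aromatic carbon. Methoxy stands in place of hydrogen on an aromatic carbon, ortho to a methoxy group and meta to a large group, turning 4-methoxyphenyl into 3,4-dimethoxyphenyl.

The series offers no measured evidence for a direction, so no change beyond the usual scatter is expected in this assay. The expected step is a 1.1-fold lower number from compound 1 to compound 4 (0.04 log units; within the scatter). For compound 4 the estimated value is 70000 nM, with an expected range of 30000 nM to 150000 nM.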

Compound 4, half-maximal inhibitory concentration: 91800 nM
Compound 4: the middle estimate sits 1.3-fold (0.12 log units) below what was measured, within the range that was stated.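

In this assay, within the data shown here, the first measured step is a 1.2-fold higher number from compound 1 to compound 4 (0.08 log units; within the scatter) and so gives the position its first reading: methoxy in place of hydrogen on an aromatic carbon, ortho to a methoxy group and meta to a large group, does not separate the two compounds. For this single pair, turning 4-methoxyphenyl into 3,4-dimethoxyphenyl leaves the read-out indistinguishable from that of the parent. No measured evidence bears on the origin of this result.

From the compounds shown here alone, whether an amine, a carboxylic acid or a longer chain such as ethoxy at this place would give a step beyond the scatter remains open. Steps to compound 2 and compound 3 cannot be read, so the other aryl positions of the series remain without a measured step.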